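Pruning the phenethyl arm of compound 2

This account rests on a few compounds, and the source may have more. Where it says the series, first, only, none or still open, it means among the compounds named here.

Two compounds of the series have been run in an assay (Equus caballus) for inhibition of Thromboxane-A synthase (Homo sapiens), using microsomes; on this read-out lower numbers stand for stronger inhibition and higher numbers for weaker inhibition. Compound 1 `O=C(O)CCCC/C=C(/c1ccccc1)c1ccccn1` returns only a limit of the assay, > 100000 nM, and no number. For the measured compounds named here, compound 2 `O=C(O)CCCC/C=C(/CCCc1ccccc1)c1cccnc1` gives 65 nM in this assay, the only number so far. The value of compound 1 is a limit of the assay. Compound 2 therefore stands alone with a real reading and has no measured partner against which it can be ranked.

Compound 3 `C/C(=C/CCCCC(=O)O)c1cccnc1` has not yet been run in this assay. It differs from compound 2 by hydrogen in place of phenethyl on a saturated chain carbon bound to a double-bonded chain carbon. Going by the values given here, no step between two measured compounds has been recorded, so the size of this change can only be judged from the one reading on compound 2 and from what leaves and what enters. The step from compound 2 to compound 3 is expected to go toward weaker inhibition and to pass beyond the usual scatter, as a 15-fold higher number from compound 2 to compound 3 (1.19 log units; beyond the scatter). For compound 3 the estimate in this assay is 1000 nM, with a range from 200 nM to 8000 nM.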

Compound 3, half-maximal inhibitory concentration: 71 nM
Compound 3: the middle estimate sits 14-fold (1.15 log units) above what was measured; measured number outside the range, below it.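

In this assay the phenethyl arm can go without a readable loss, with the change running as a 1.1-fold higher number from compound 2 to compound 3 (0.04 log units; within the scatter) and taking its 8 heavy atoms and six-membered aromatic ring with it. On this pair, the saturated chain carbon bound to a double-bonded chain carbon carries either hydrogen or phenethyl with no resolved difference in inhibition, so the simpler compound 3 can serve as the reference for this position in place of compound 2. No measurement at hand bears on why these two readings agree.

The compounds shown leave open whether an intermediate group at this place, such as a plain ethyl group or a short chain ending in an amine or a hydroxyl group, would also stay within the scatter of compound 3 or would move the number beyond it. They also leave open how far the reading of compound 3 depends on its carboxylic acid side chain, which a shorter or longer chain ending in the same acid would test in a single change.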